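Swapping the 4-Methoxyphenyl Group in a Gastric Cancer Cell Series

The source may report more compounds than this note shows. Statements on the series, on what has been measured and on what is new or still open speak of the compounds shown alone.

Compound 1 `COc1ccc(/C=N/NC(=O)CSc2nnc(-c3ccncc3)o2)cc1`: 19800 nM
Compound 2 `O=C(CSc1nnc(-c2ccncc2)o1)N/N=C/c1cccc(C(F)(F)F)c1`: 13000 nM

In a functional assay on BGC-823 cells (Homo sapiens) for cytotoxicity, read by MTT assay, with a stated time of 48 h (on this read-out lower numbers stand for stronger inhibition and higher numbers for weaker inhibition), compound 1 gives 19800 nM, the highest of the two numbers shown, while compound 2 gives 13000 nM; the gap between them lies within the usual scatter, so the two stand level. Compound 3 `O=C(CSc1nnc(-c2ccncc2)o1)N/N=C/c1cc(Cl)cc(Cl)c1O` is not yet measured; it differs from compound 1 by 3,5-dichloro-2-hydroxyphenyl in place of 4-methoxyphenyl on a carbon with a double bond to nitrogen. Going by the values given here, no measured pair follows this change, so the step is expected from the structural change alone: a modest lowering, a 2.5-fold lower number from compound 1 to compound 3 (0.39 log units; beyond the scatter), somewhat beyond the scatter. Compound 3 is estimated at 8000 nM, with a range from 2500 nM to 25000 nM.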

Compound 3, half-maximal inhibitory concentration: 6340 nM
Beside the measured number, compound 3's estimate is 1.3-fold (0.10 log units) above it; low and high end bracket the measured number.
By their numbers in this assay, from the lowest: compound 3; then compounds 2 and 1 (each within the scatter of the next).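

In this assay, the place on the carbon with a double bond to nitrogen proves able to move the number beyond the scatter: 3,5-dichloro-2-hydroxyphenyl in place of 4-methoxyphenyl gives a modest step (a 3.1-fold lower number from compound 1 to compound 3 (0.49 log units; beyond the scatter)). Going by these compounds alone, compounds 1 and 2 had stood level, so this is the first change here that exceeds the scatter. Nothing measured here explains the step.

From the compounds shown here alone, the chlorine atoms and the hydroxyl enter together, so their separate shares remain open. Going by these compounds, it also remains open how a phenyl carrying only the hydroxyl, only chlorine or an amine would compare.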